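The source may report more compounds than this note shows. Statements on the series, on what has been measured and on what is new or still open speak of the compounds shown alone.

Working notes on the series.

Compound 3 `CCCCCCCCCCn1cc(/C=C/C(=O)c2ccc(N)cc2)nn1` is the unsubstituted amine of the first core; in a functional assay on A549 cells (Homo sapiens) for inhibition, read by MTT assay (on this read-out lower numbers stand for stronger inhibition and higher numbers for weaker inhibition), compound 3 gives 35600 nM. Compound 1 `CCCCCCCCCCn1cc(/C=C/C(=O)c2ccc(NC(=O)CBr)cc2)nn1` differs from compound 3 in one place, ((bromomethyl)carbonyl in place of hydrogen on a nitrogen on an aromatic ring). In this assay compound 1 gives 9740 nM, and the step is a 3.7-fold lower number from compound 3 to compound 1 (0.56 log units; beyond the scatter).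

Compound 2 `Nc1ccc(C(=O)/C=C/c2cn(Cc3ccc(Br)cc3)nn2)cc1` is the unsubstituted amine of a second core; the difference between the two cores is not broken down here. In this assay compound 2 gives 15800 nM. Its number and that of compound 1 lie within the scatter of each other, so no order is drawn between them; the number of compound 3 is higher than that of compound 2 by a gap beyond the scatter.

Compound 4 `O=C(CBr)Nc1ccc(C(=O)/C=C/c2cn(Cc3ccc(Br)cc3)nn2)cc1` is the pending compound and stands to compound 2 as compound 1 stands to compound 3: (bromomethyl)carbonyl in place of hydrogen on a nitrogen on an aromatic ring. The place of the change is described in the same words for both pairs, so this is the same change made on a second core; it occurs in two pairs among the compounds shown, only one of them measured.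

For the measured compounds named here, a step of about the same size, a 3.5-fold lower number from compound 2 to compound 4 (0.55 log units; beyond the scatter), is expected, because the one instance of this change for which a number exists gave a 3.7-fold lower number from compound 3 to compound 1 (0.56 log units; beyond the scatter). The expectation rests on a single pair and on a core difference that is not broken down, so a wide spread is kept. Compound 4 is expected to give about 4500 nM in this assay, estimated to lie between 1500 nM and 13000 nM.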

Compound 4, half-maximal inhibitory concentration: 8670 nM
Compound 4: middle estimate off by 1.9-fold (0.28 log units), on the low side; low and high end bracket the measured number.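

In this assay the step on the second core, a 1.8-fold lower number from compound 2 to compound 4 (0.26 log units; within the scatter), stays within the scatter, whereas the step on the first core lies beyond it, yet the two steps cannot be told apart: the same change on two cores in this assay, a 3.7-fold lower number (0.56 log units; beyond the scatter) from compound 3 to compound 1 and a 1.8-fold lower number (0.26 log units; within the scatter) from compound 2 to compound 4, 2.0-fold (0.30 log units) apart, within the scatter of two such steps

For the compounds shown here, this shows that the numbers are compatible with (bromomethyl)carbonyl in place of hydrogen carrying over from one core to the other at a similar size, but it does not show that the change transfers, as only two pairs exist and the step on the second core cannot by itself be separated from the scatter. With (bromomethyl)carbonyl present on both cores, 4-bromophenyl in place of nonyl gives a 1.1-fold lower number from compound 1 to compound 4 (0.05 log units; within the scatter), so no order can be drawn between these two compounds, and this single pair says nothing about other groups at that place.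

The compounds shown leave open whether acetyl or (chloromethyl)carbonyl on that nitrogen would give a step of like size on either core, which would indicate how much of the step goes with the bromine. Also open, on these data alone, is how the step would behave with a shorter chain or a 4-chlorophenyl in place of nonyl or 4-bromophenyl.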